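Cyclohexyl for methyl on the shared core: compound 4

This account rests on a few compounds, and the source may have more. Where it says the series, first, only, none or still open, it means among the compounds named here.

Compound 3 `CNc1nc(NCc2ccc(F)cc2)n2nc(-c3ccco3)nc2n1` carries the shared core with a methylamino group on one side and a 4-fluorobenzyl group on a second ring nitrogen. In a functional assay on CHO cells for antagonist activity at adenosine receptor A2b (Homo sapiens) (a lower number here means a stronger inhibitor, a higher number a weaker inhibitor), compound 3 gives only a limit, > 30000 nM. Compound 1 `CNc1nc(N)n2nc(-c3ccco3)nc2n1` lacks the 4-fluorobenzyl group. In this assay compound 1 likewise gives only a limit, > 30000 nM. The step between these two cannot be sized: a step that the two limits leave unreadable from compound 1 to compound 3. Compound 2 `c1coc(-c2nc3nc(NC4CCCCC4)nc(NC4CCCCC4)n3n2)c1` carries cyclohexylamino groups on both sides of the core and is the nearest neighbour to the change at hand. In this assay compound 2 also gives only a limit, > 30000 nM. Going by the values given here, all values so far sit at one and the same limit (the limit of > 30000 nM in this assay, at which 3 of the 3 values shown sit), so no measured step is readable, and nothing places compound 3 above or below its neighbours.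

Compound 4 `Fc1ccc(CNc2nc(NC3CCCCC3)nc3nc(-c4ccco4)nn23)cc1` differs from compound 3 in one place: cyclohexyl in place of methyl on a nitrogen on an aromatic ring. Among the compounds with values here, no measured step bears on this change. Within the data shown here, the only guidance is that compound 2, which carries a cyclohexylamino group, also reached no reading. The step from compound 3 to compound 4 is therefore expected to be a number no higher from compound 3 to compound 4 (the limit leaves the size open), with no change beyond the scatter anticipated. Compound 4 is expected at 30000 nM, within a range from 8000 nM to 100000 nM, and most probably only a limit will again be reported.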

Compound 4, half-maximal inhibitory concentration: > 30000 nM
Compound 4 ended at the assay's limit; the forecaster's own chance of this, stated with the estimate: 75%; the middle value lies on the limit itself.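

Neither the step from compound 3 to compound 4 nor the step from compound 2 to compound 4 can be read, because each compares two limits: the limit of > 30000 nM in this assay, at which 4 of the 4 values shown sit.

The compounds shown leave open which group on the shared core, if any, would bring a compound to a readable value in this assay.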